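A few compounds are considered here, and "the series" means these few. Any claim that something is new, unique, unknown or untested is made for them only; others in the source may bear on it.

Measured compounds:
- compound 1, `CC(C)CCCCCCCCCCCCC(=O)NCC(=O)N[C@@H]1[C@@H](O)[C@H](O)[C@@H](Nc2ncnc3[nH]cnc23)O[C@H]1CO`, in a functional assay on L1210 cells (Mus musculus) for cytotoxicity (on this read-out higher numbers stand for weaker inhibition and lower numbers for stronger inhibition), gives > 10000 nM
- compound 2, `CCCCCCCCCCCCCCCC(=O)NCC(=O)N[C@@H]1[C@@H](O)[C@H](O)[C@@H](Nc2ncnc3[nH]cnc23)O[C@H]1CO`, gives > 100000 nM
- compound 3, `CCCCCCCCCCCC(=O)NCC(=O)N[C@@H]1[C@@H](O)[C@H](O)[C@@H](Nc2ncnc3[nH]cnc23)O[C@H]1CO`, gives 3000 nM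

The value of compound 1 is a limit of this assay, not a number; it sits at the limit of > 10000 nM in this assay, at which 1 of the 3 values shown sits. Compound 2 likewise stands at a limit, (the limit of > 100000 nM in this assay, at which 1 of the 3 values shown sits). Compound 3 is the only one of the three with a numeric reading.

Compound 4, `CC(C)CCCCCCCCCCCCC(=O)NCC(=O)N[C@@H]1[C@@H](O)[C@H](O)[C@@H](Nc2ncnc3[nH]cnc23)O[C@H]1C`, differs from compound 1 in one place: hydrogen in place of hydroxy on a saturated chain carbon bound to a saturated ring carbon. For the measured compounds named here, none of the measured steps touches this part of the molecule. The steps that were measured all lie at the far end of the chain: an at least 3.3-fold lower number from compound 1 to compound 3 (0.52 log units; beyond the scatter), an at least 33-fold lower number from compound 2 to compound 3 (1.52 log units; beyond the scatter), while a step that the two limits leave unreadable from compound 1 to compound 2. They say nothing about the hydroxy on the ring-bound chain carbon, so no step beyond the scatter is expected from this change in this assay.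

Compound 4 is therefore estimated to stand where compound 1 stands, at about 15000 nM, in the range 4000 nM to 100000 nM, which means a step that the limit leaves unreadable from compound 1 to compound 4, and most likely the assay again reports only a limit.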

Compound 4, half-maximal inhibitory concentration: > 20000 nM
Compound 4 gave a limit, no number; the forecaster's own chance of this, stated with the estimate: 70%; middle value at least 1.3-fold (0.12 log units) from the limit.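

In this assay compound 4 gives > 20000 nM, which is a limit and not a number. Compound 1 also stands at a limit, > 10000 nM, so the step between compound 1 and compound 4 cannot be read. The compounds shown leave open whether hydrogen in place of hydroxy on this saturated chain carbon changes cytotoxicity at all.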